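Extending the Alkyl Chain on a Shared Core

The source may report more compounds than this note shows. Statements on the series, on what has been measured and on what is new or still open speak of the compounds shown alone.

Of the compounds shown here, three sharing one core have been measured in a functional assay on brain (Rattus norvegicus, strain Wistar) for inhibition; a lower number here means a stronger inhibitor, a higher number a weaker inhibitor. Compound 1 `CCCCCCOc1ccc(-c2c(C)[nH]c(=O)n2C)cc1` gives 7300 nM. Compound 2 `CCCCCCCCOc1ccc(-c2c(C)[nH]c(=O)n2C)cc1`, in this assay, gives 4000 nM. The change between them is ethyl in place of hydrogen on a saturated chain carbon, six bonds along the chain from an oxygen on an aromatic ring, and the step it made is a 1.8-fold lower number from compound 1 to compound 2 (0.26 log units; within the scatter). Compound 3 `CCCCCCCCCCc1ccc(-c2c(C)[nH]c(=O)n2C)cc1` carries its chain without the oxygen; the difference between the cores of compound 1 and compound 3 is not broken down here. In this assay compound 3 gives 7900 nM, and what the three numbers show is that all of them lie within the scatter of one another.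

Compound 4 `CCCCCCCCCCCCc1ccc(-c2c(C)[nH]c(=O)n2C)cc1` has not yet been measured. Relative to compound 3 the change is ethyl in place of hydrogen on a saturated chain carbon, ten or more bonds along the chain from an aromatic carbon. This is the same kind of change as from compound 1 to compound 2, but the place along the chain differs, as the two descriptions of the differences show. Because a 1.8-fold lower number from compound 1 to compound 2 (0.26 log units; within the scatter), a step of similar size is expected here, namely a 1.6-fold lower number from compound 3 to compound 4 (0.20 log units; within the scatter). Compound 4 is therefore estimated at 5000 nM, within a range from 2000 nM to 15000 nM.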

Compound 4, half-maximal inhibitory concentration: 13000 nM
The estimate for compound 4 lay 2.6-fold (0.41 log units) below the measured number, within the range that was stated.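

The new measurement in this assay shows a 1.6-fold higher number from compound 3 to compound 4 (0.22 log units; within the scatter). Set beside the earlier step, ethyl in place of hydrogen did not carry over from one core to the other with the same size and direction, so the earlier step cannot simply be transferred to the core of compound 3: the same change on two cores in this assay, a 1.8-fold lower number (0.26 log units; within the scatter) from compound 1 to compound 2 and a 1.6-fold higher number (0.22 log units; within the scatter) from compound 3 to compound 4, 3.0-fold (0.48 log units) apart, beyond the scatter of two such steps. The two steps differ both in the core and in the place on the chain, and with a single step on each core the data do not separate these two differences or show which of them goes with the gap, nor do they establish a trend with chain length on either core.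

The compounds shown leave open how a still longer chain would behave on either core. They also leave open what an amine or a carboxylic acid at the end of the chain would do in this assay.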